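Hydrazide urea series: swapping the aryl on the urea nitrogen

The compounds below may be only part of what the source reports. "The series", "measured", "known", "first", "only" and "open" are said of these compounds alone.

Measured so far in a functional assay on HCT-116 cells (Homo sapiens) for cytotoxicity, read by MTT assay, with a stated time of 48 h, in the presence of a further agent that is not named here; a lower number here means that less compound is needed, a higher number that more compound is needed for the effect:
compound 1 `Cn1ncc2c(-c3ccccc3)cc(NNC(=O)Nc3cc(Cl)nc(Cl)c3)nc21`: 6240 nM
compound 2 `COc1cc(NC(=O)NNc2cc(-c3ccc(F)cc3)c3cnn(C)c3n2)cc(Cl)n1`: 75300 nM
compound 3 `Cn1ncc2c(-c3ccc(F)cc3)cc(NNC(=O)Nc3cc(F)cc(F)c3)nc21`: 46200 nM

Compound 3 gives the second highest of the three numbers in this assay. Within the data shown here, its nearest neighbour is compound 2, whose number lies within the scatter of it; the step of a 1.6-fold lower number from compound 2 to compound 3 (0.21 log units; within the scatter) is the only one-place change measured so far and is itself within the scatter. Compound 1 lies furthest away, with a number well below that of compound 3.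

The next compound, compound 4 `Cn1ncc2c(-c3ccc(F)cc3)cc(NNC(=O)Nc3cc(Cl)nc(Cl)c3)nc21`, differs from compound 3 by 2,6-dichloropyridin-4-yl in place of 3,5-difluorophenyl on an amide-type nitrogen.

Among the measured compounds shown here, no measured step bears directly on this change. The step of a 1.6-fold lower number from compound 2 to compound 3 (0.21 log units; within the scatter) shows that a pyridinyl-type group in place of the difluorophenyl need not move the number beyond the scatter. Compound 1, however, carries the same 2,6-dichloropyridin-4-yl group on its amide-type nitrogen, though it differs from compound 4 elsewhere. In this assay compound 1 gives 6240 nM, the lowest of the set. On that basis a lower number is expected for compound 4 than for compound 3, by a step of about a 4.6-fold lower number from compound 3 to compound 4 (0.66 log units; beyond the scatter).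

Compound 4 is therefore estimated at 10000 nM, with a plausible range from 4000 nM to 30000 nM.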

Compound 4, half-maximal effective concentration: 8210 nM
Estimate against measurement, compound 4: 1.2-fold (0.09 log units) above; the range from low to high includes it.
By their numbers in this assay, from the lowest: compounds 1 and 4 (each within the scatter of the next); then compounds 3 and 2 (each within the scatter of the next).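

In this assay, among these compounds, the amide-type nitrogen of the urea now shows a clear response to its aryl group: a 5.6-fold lower number from compound 3 to compound 4 (0.75 log units; beyond the scatter), for 2,6-dichloropyridin-4-yl in place of 3,5-difluorophenyl, is the first one-place change here that lies beyond the scatter. The pyridinyl ring alone does not set the number, since compound 2 stays within the scatter of compound 3, whereas a 9.2-fold lower number from compound 2 to compound 4 (0.96 log units; beyond the scatter) comes with chloro in place of methoxy on an aromatic carbon and also lies beyond the scatter. The other one-place step, a 1.3-fold higher number from compound 1 to compound 4 (0.12 log units; within the scatter), for fluoro in place of hydrogen on an aromatic carbon, stays within the scatter, so the 2,6-dichloropyridin-4-yl group keeps compound 1 and compound 4 together at the low end of the set whether or not that fluoro is present.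

The compounds shown leave open whether both chloro groups are needed, and how an amine, a nitrile or a methyl group in place of one chloro of the 2,6-dichloropyridin-4-yl group would read in this assay. Nothing in the data at hand speaks to the reason for these steps.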